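The source may hold more compounds than are shown below. What is called first, only, known or untested is meant among the compounds shown, and "the series" means these compounds.

Measured in an ADME assay on RAW264.7 cells (Mus musculus) for cytotoxicity, read by MTT assay, with a stated time of 24 h (a higher number here means that more compound is tolerated, a lower number that less compound is tolerated), so far:
- compound 1 `CC/C=C\C[C@H]1C(=O)C=C[C@H]1CC(=O)OCCC` gives 35 uM
- compound 2 `CC/C=C\C[C@H]1C(=O)C=C[C@H]1CC(=O)OCCCC` gives 31 uM
- compound 3 `CC/C=C\C[C@H]1C(=O)C=C[C@H]1CC(=O)OC(C)C` gives 58 uM

Compound 3 does not stand apart from the other two on these numbers: the step of a 1.7-fold higher number from compound 1 to compound 3 (0.22 log units; within the scatter) and the step of a 1.9-fold higher number from compound 2 to compound 3 (0.27 log units; within the scatter) both stay within the scatter. Still unmeasured is compound 4 (`CC/C=C\C[C@H]1C(=O)C=C[C@H]1CC(=O)OC1CCCCC1`), which has cyclohexyl in place of isopropyl on an oxygen next to a carbonyl group. Those two steps bear on it most directly, since both swap the group on that same oxygen. Compound 2 adds the step of a 1.1-fold lower number from compound 1 to compound 2 (0.05 log units; within the scatter) on the same group, also within the scatter. Within the data shown here, no measured compound carries a ring there, so the evidence is indirect. No step beyond the scatter is therefore expected in this assay for this change. The expected step is a 1.5-fold lower number from compound 3 to compound 4 (0.16 log units; within the scatter) by estimate. Compound 4 is estimated at 40 uM with 18 uM to 85 uM as the expected range.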

Compound 4, half-maximal toxic concentration: 31 uM
The estimate for compound 4 lay 1.3-fold (0.11 log units) above the measured number, and the stated range covers the measured number.
By their numbers in this assay, from the lowest: compounds 2, 4, 1 and 3 (each within the scatter of the next).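

In this assay, cyclohexyl is the only ring on an oxygen next to a carbonyl group, and it stays within the scatter of each group without a ring: isopropyl (a 1.9-fold lower number from compound 3 to compound 4 (0.27 log units; within the scatter)), butyl (no change at the digits printed from compound 2 to compound 4 (within the scatter)) and propyl (a 1.1-fold lower number from compound 1 to compound 4 (0.05 log units; within the scatter)). On the compounds shown, this position therefore takes a change from 3 heavy atoms to 6 heavy atoms, and the addition of a six-membered non-aromatic ring of carbon only, with no step beyond the scatter. Nothing available explains the small differences among these four compounds.

On these data alone, whether phenyl, an amine or a chain longer than butyl on the same oxygen would give a step beyond the scatter remains open. The compounds shown also leave open how a free carboxylic acid in place of the ester would read.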